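The source may hold more compounds than are shown below. What is called first, only, known or untested is meant among the compounds shown, and "the series" means these compounds.

Measured so far in an ADME assay on MT4 cells (Homo sapiens) for cytotoxicity, read by MTT assay, with a stated time of 4 days; a lower number here means that less compound is tolerated, a higher number that more compound is tolerated:
Compound 1 `CCOC(=O)c1cnc(N2CCN(Cc3ccccc3C(F)(F)F)CC2)nc1Oc1c(C)cc(-c2ccc(C#N)cc2)cc1C` gives > 125000 nM, which is a limit of the assay rather than a number.
Compound 2 `CCOC(=O)c1cnc(N2CCN(Cc3cccc([N+](=O)[O-])c3)CC2)nc1Oc1c(C)cc(-c2ccc(C#N)cc2)cc1C` gives > 125000 nM, also a limit.
Compound 3 `CCOC(=O)c1cnc(N2CCN(Cc3cccc(C(N)=O)c3)CC2)nc1Oc1c(C)cc(-c2ccc(C#N)cc2)cc1C` gives 14800 nM.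

Compound 1 therefore stands only at a limit, as does one of the two other values; only compound 3 gives a number. Compound 4 `CCOC(=O)c1cnc(N2CCN(Cc3ccc(S(C)(=O)=O)cc3)CC2)nc1Oc1c(C)cc(-c2ccc(C#N)cc2)cc1C` differs from compound 1 by 4-(methylsulfonyl)phenyl in place of 2-(trifluoromethyl)phenyl on a saturated chain carbon bound to an amine nitrogen in a ring. Two measured steps start from compound 1: a step that the two limits leave unreadable from compound 1 to compound 2, and an at least 8.4-fold lower number from compound 1 to compound 3 (0.92 log units; beyond the scatter). The step of an at least 8.4-fold lower number from compound 2 to compound 3 (0.92 log units; beyond the scatter) shows the same drop from the other limit. Because two of three values sit at the limit of > 125000 nM in this assay, at which 2 of the 3 values shown sit, a limit is again likely for compound 4, though a number is possible. For compound 4 a step of an at least 1.3-fold lower number from compound 1 to compound 4 (0.14 log units; that floor lies within the scatter) is therefore expected. The estimate for compound 4 is 90000 nM, between 25000 nM and 300000 nM.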

Compound 4, half-maximal cytotoxic concentration: > 125000 nM
Compound 4 was reported as a limit; the forecaster's own chance of this, stated with the estimate: 55%; middle value at least 1.3-fold (0.14 log units) from the limit.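

In this assay, among the compounds shown here, compound 4 also gives only a limit of the assay, not a number, and this now holds for a third substituted benzyl group at this position: the limit of > 125000 nM in this assay, at which 3 of the 4 values shown sit. The new substituent can be compared only with compound 3, the one compound with a number, and that comparison shows an at least 8.4-fold higher number from compound 3 to compound 4 (0.92 log units; beyond the scatter). The steps among compounds 1, 2 and 4 join two limits and cannot be read.

From the compounds shown here alone, how far compounds 1, 2 and 4 lie past the limit stays open. So does whether an amine or a carboxylic acid on this benzyl ring would give a number, as the carbamoyl group of compound 3 does.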